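Cytotoxicity of Thiadiazole Amides: Predicting a Methylphenyl Analogue

A few compounds are considered here, and "the series" means these few. Any claim that something is new, unique, unknown or untested is made for them only; others in the source may bear on it.

Three amides built on a shared core have been examined in an ADME assay on MRC5 cells (Homo sapiens) for cytotoxicity, read by MTT assay, with a stated time of 72 h; on this read-out lower numbers stand for stronger inhibition and higher numbers for weaker inhibition. Compound 1 `O=C(Nc1nnc(-c2cccc(O)c2O)s1)c1ccccc1` carries a phenyl on the carbonyl carbon, and compound 1 gives 23200 nM. Compound 2 `O=C(Nc1nnc(-c2cccc(O)c2O)s1)C1CCCCC1` bears a cyclohexyl in its place, and compound 2 gives 70300 nM. Compound 3 `CC(=O)Nc1nnc(-c2cccc(O)c2O)s1`, the acetyl analogue, gives 156000 nM, the highest number of the three; its nearest neighbour is compound 2 and its furthest is compound 1, as shown by a 2.2-fold higher number from compound 2 to compound 3 (0.35 log units; beyond the scatter) and a 6.7-fold higher number from compound 1 to compound 3 (0.83 log units; beyond the scatter).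

Compound 4 `Cc1ccc(C(=O)Nc2nnc(-c3cccc(O)c3O)s2)cc1` has not yet been measured. The change from compound 3 is 4-methylphenyl in place of methyl on a carbonyl carbon. Within the data shown here, the step most relevant to it is a 6.7-fold higher number from compound 1 to compound 3 (0.83 log units; beyond the scatter), since compound 4, like compound 1, places an aromatic ring on the carbonyl carbon; the added methyl on that ring is the only difference between compound 4 and compound 1, and no measured step addresses such a substituent directly. Reversing the direction of that step, compound 4 is expected to show a number close to that of compound 1, giving an estimated 8.7-fold lower number from compound 3 to compound 4 (0.94 log units; beyond the scatter). Compound 4 is therefore estimated at 18000 nM, with a range from 6000 nM to 60000 nM.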

Compound 4, half-maximal inhibitory concentration: 33200 nM
Compound 4: middle estimate off by 1.8-fold (0.27 log units), on the low side; low and high end bracket the measured number.
By their numbers in this assay, from the lowest: compounds 1 and 4 (each within the scatter of the next); then compound 2; then compound 3.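

In this assay, a 4-methylphenyl on the carbonyl carbon gives a clearly lower number than either non-aromatic group, with a 4.7-fold lower number from compound 3 to compound 4 (0.67 log units; beyond the scatter) and a 2.1-fold lower number from compound 2 to compound 4 (0.33 log units; beyond the scatter), so the low number of compound 1 is no longer the only case of an aromatic ring at this place giving a lower number than the methyl and cyclohexyl groups. The new information is that the ring tolerates a substituent in this read-out: methyl in place of hydrogen on an aromatic carbon gives a 1.4-fold higher number from compound 1 to compound 4 (0.16 log units; within the scatter), which lies within the scatter, so this single added methyl cannot be said to change the number. Nothing given here explains why these groups differ.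

The compounds shown leave open whether this tolerance extends beyond methyl, for example to a methoxy group, a chlorine atom or a carboxylic acid on the same ring, since a single substituent at a single ring place cannot define a trend. They also leave open how a longer chain or an amine on the carbonyl carbon would compare with the phenyl, cyclohexyl and methyl groups.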